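A few compounds are considered here, and "the series" means these few. Any claim that something is new, unique, unknown or untested is made for them only; others in the source may bear on it.

Compound 1 `CC(C)c1noc(N2CCC([C@H]3C[C@H]3COCc3ccc(S(C)(=O)=O)cc3F)CC2)n1` gives 9.9 nM in a functional assay on isolated protein for agonist activity at Glucose-dependent insulinotropic receptor (Mus musculus), read by cAMP accumulation; a higher number here means that more compound is needed for the effect, a lower number that less compound is needed. Compound 2 `CC(C)c1noc(N2CCC([C@H]3C[C@H]3COCc3ccc(-n4cnnn4)cc3F)CC2)n1` carries the change 1H-tetrazol-1-yl in place of methylsulfonyl on an aromatic carbon and gives 4.8 nM in this assay, a step of a 2.1-fold lower number from compound 1 to compound 2 (0.31 log units; beyond the scatter). Compound 3 `COCc1cnc(N2CCC([C@H]3C[C@H]3COCc3ccc(S(C)(=O)=O)c(F)c3)CC2)nc1` gives 5.2 nM in this assay; the difference between the core of compound 3 and the core of compound 1 is not broken down here. Compound 4 `COCc1cnc(N2CCC([C@H]3C[C@H]3COCc3ccc(-n4cnnn4)c(F)c3)CC2)nc1` is not yet measured and carries the change (1H-tetrazol-1-yl in place of methylsulfonyl on an aromatic carbon). The place differs from the earlier case: there the entering group stood meta to a fluoro group, here it stands ortho to a fluoro group, so this is the same kind of change, not the same. The step from compound 3 to compound 4 is expected to be a 1.7-fold lower number from compound 3 to compound 4 (0.24 log units; within the scatter), resting on compound 1 and compound 2, where the step was a 2.1-fold lower number from compound 1 to compound 2 (0.31 log units; beyond the scatter). Compound 4 is therefore expected to give about 3 nM in this assay, within 1.2 nM to 7.5 nM.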

Compound 4, half-maximal effective concentration in the Glucose-dependent insulinotropic receptor assay: 3.8 nM
For compound 4 the middle estimate is 1.3-fold (0.10 log units) below the measured one; the measured number falls inside the stated range.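

In the Glucose-dependent insulinotropic receptor assay replacing methylsulfonyl with 1H-tetrazol-1-yl gives a 1.4-fold lower number from compound 3 to compound 4 (0.14 log units; within the scatter). In a physicochemical assay for solubility, in simulated intestinal fluid, measured as kinetic solubility, at pH 6.5 (a lower number here means a less soluble compound, a higher number a more soluble compound), compound 3 gives 155000 nM and compound 4 gives 133000 nM. In the physicochemical assay the same replacement gives a 1.2-fold lower number from compound 3 to compound 4 (0.07 log units; within the scatter). Set beside the earlier pair, the change carries across the two cores with no difference that can be told apart: the same change on two cores in the Glucose-dependent insulinotropic receptor assay, a 2.1-fold lower number (0.31 log units; beyond the scatter) from compound 1 to compound 2 and a 1.4-fold lower number (0.14 log units; within the scatter) from compound 3 to compound 4, 1.5-fold (0.18 log units) apart, within the scatter of two such steps This rests on only two pairs, which also differ in where the fluoro group stands, so it shows no general rule and cannot separate the effect of the core from that of the fluoro placement.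

Still open, from the compounds shown here alone, is whether a carboxylic acid, an amine or a nitrile in place of methylsulfonyl would follow the same course. Also open, going by these compounds, is whether the change carries to cores beyond these two.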